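Chain amines with a bis(trifluoromethyl)phenylsulfonamide head

The source may hold more compounds than are shown below. What is called first, only, known or untested is meant among the compounds shown, and "the series" means these compounds.

Measured so far:
compound 1 `O=S(=O)(NCCNCc1cccc2ccccc12)c1cc(C(F)(F)F)cc(C(F)(F)F)c1` — 24000 nM
compound 2 `CC(C)(C)c1ccc(CNCCCNS(=O)(=O)c2cc(C(F)(F)F)cc(C(F)(F)F)c2)cc1` — 2500 nM
compound 3 `O=S(=O)(NCCNCc1ccc(-c2ccccc2)cc1)c1cc(C(F)(F)F)cc(C(F)(F)F)c1` — 4200 nM

All three numbers come from a functional assay on PANC-1 cells (Homo sapiens) for inhibition, read by MTT assay, with a stated time of 72 h; on this read-out higher numbers stand for weaker inhibition of growth and lower numbers for stronger inhibition of growth. Compound 2 stands at the lowest of the three numbers. Compound 3 lies within the usual scatter of it, so the two cannot be ordered on these data. Compound 1 lies beyond the scatter, at the highest number of the set.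

The next compound, compound 4 `O=S(=O)(NCCCNCc1ccc(Cl)c(Cl)c1)c1cc(C(F)(F)F)cc(C(F)(F)F)c1`, has not been measured in this assay. It departs from compound 2 in one place: 3,4-dichlorophenyl in place of 4-(tert-butyl)phenyl on a saturated chain carbon bound to an amine nitrogen. Between the two no measured step exists in the series, and none of the measured pairs isolates this exchange, so the direction can only be guessed. The arylmethyl part varies across compounds 1 to 3 with numbers spanning beyond the scatter, which shows that this position matters for the read-out, but the three compounds give no trend that carries over to a dichlorophenyl group.

Working expectation: a step from compound 2 to compound 4 of a 1.8-fold higher number from compound 2 to compound 4 (0.26 log units; within the scatter), that is, a modest rise in the number, not clearly beyond the scatter. For compound 4 the estimate in this assay is 4500 nM, with a range from 1500 nM to 14000 nM.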

Compound 4, concentration for 50% growth inhibition: 5600 nM
Beside the measured number, compound 4's estimate is 1.2-fold (0.09 log units) below it; measured number inside the range.
By their numbers in this assay, from the lowest: compounds 2, 3 and 4 (each within the scatter of the next, the first and the last beyond it); then compound 1.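

In this assay, among the compounds shown here, the exchange of 4-(tert-butyl)benzyl for 3,4-dichlorobenzyl gives a 2.2-fold higher number from compound 2 to compound 4 (0.35 log units; beyond the scatter) and provides the first measured step at this position, on a saturated chain carbon bound to an amine nitrogen. The number therefore responds to the substituents on the aromatic ring even though both groups keep one six-membered aromatic ring of carbon only, while the group falls from 10 heavy atoms to 8, though the modest size of the step shows only a limited response for this one exchange. No measured property on these compounds accounts for the step.

These compounds do not separate the loss of the tert-butyl group from the arrival of the two chlorine atoms, and an unsubstituted benzyl group or a 4-chlorobenzyl group on the same chain would be needed to divide the step into those two parts. On these data alone, it also remains open whether the same exchange gives a step of similar direction and size with a longer chain, or with an amide in place of the amine.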